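Imine to (2-hydroxybenzyl)amino in the serine amide series

The compounds below may be only part of what the source reports. "The series", "measured", "known", "first", "only" and "open" are said of these compounds alone.

Working notes. In a functional assay on cells (Homo sapiens) for cytotoxicity, read by MTT assay, with a stated time of 24 h (a higher number here means a weaker inhibitor, a lower number a stronger inhibitor), compound 1 `CCCCCCCCCCCCCCNC(=O)[C@H](CO)/N=C/c1ccccc1` gives 7670 nM, the lowest of the two numbers in hand. Among the measured compounds shown here, compound 2 `CCCCCCCCCCCCCCNC(=O)[C@H](CO)/N=C/c1ccccc1[N+](=O)[O-]` gives 21700 nM in this assay, and the single measured step, a 2.8-fold higher number from compound 1 to compound 2 (0.45 log units; beyond the scatter), is the introduction of the nitro group.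

Compound 3 `CCCCCCCCCCCCCCNC(=O)[C@H](CO)NCc1ccccc1O` is not yet measured. Against compound 1 the change is a group of 9 heavy atoms (7 carbon, 1 nitrogen, 1 oxygen; one six-membered aromatic ring of carbon only) in place of a group of 8 heavy atoms (7 carbon, 1 nitrogen; one six-membered aromatic ring of carbon only), on a saturated chain carbon bound to a carbonyl carbon and a saturated chain carbon. The double bond outside aromatic rings leaves, and the ring of the entering (2-hydroxybenzyl)amino group carries a hydroxy group.

For the measured compounds named here, the step from compound 1 to compound 2 bears on this only loosely: it shows that decorating the ring of compound 1 gave a modest weakening, but no measured pair covers the change at the saturated chain carbon bound to the carbonyl carbon. Given that the only precedent is a weakening, a small rise in the number is expected for compound 3, not clearly beyond the scatter: a 1.4-fold higher number from compound 1 to compound 3 (0.16 log units; within the scatter). Compound 3 is estimated at 11000 nM, with a range of 3500 nM to 35000 nM.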

Compound 3, half-maximal inhibitory concentration: 75300 nM
Compound 3: middle estimate off by 6.8-fold (0.84 log units), on the low side; the measured number lies above the stated range.
By their numbers in this assay, from the lowest: compound 1; then compound 2; then compound 3.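

In this assay, among the compounds shown here, this is the first measured change on the saturated chain carbon bound to a carbonyl carbon and a saturated chain carbon, and it gives a 9.8-fold higher number from compound 1 to compound 3 (0.99 log units; beyond the scatter); the only earlier step, a 2.8-fold higher number from compound 1 to compound 2 (0.45 log units; beyond the scatter), was a change on the aromatic ring. The position is therefore not indifferent to what is attached: with the double bond outside aromatic rings gone and the (2-hydroxybenzyl)amino group in place, the compound is a weaker inhibitor in this read-out, so the imine of compound 1 is the better of the two linkages measured here. No measurement in hand explains this shift, and the cause remains unassigned.

From the compounds shown here alone, the step changes two things at once, the loss of the double bond and the arrival of the hydroxy group, so their separate contributions remain open. A plain benzylamino group without the hydroxy group, or the imine of compound 1 with a hydroxy group on its ring, would separate the two, while a primary amine at this carbon would show how much of the aromatic group is needed at all.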